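The source may hold more compounds than are shown below. What is called first, only, known or untested is meant among the compounds shown, and "the series" means these compounds.

Compound 2, `O=C(/C=C/c1cc2ccccc2[nH]c1=O)c1ccc(O)cc1`, is measured in a functional assay on TK-10 cells (Homo sapiens) for cytotoxicity, read by sulforhodamine B assay, with a stated time of 24 h (on this read-out lower numbers stand for stronger inhibition of growth and higher numbers for weaker inhibition of growth), where compound 2 gives 3810 nM. Among the two numbers in hand this is the higher one, but its only neighbour, compound 1, `COc1ccc(C(=O)/C=C/c2cc3ccccc3[nH]c2=O)cc1`, stands close: in this assay compound 1 gives 3540 nM, and the step of a 1.1-fold higher number from compound 1 to compound 2 (0.03 log units; within the scatter), a hydrogen in place of a methyl on an oxygen on an aromatic ring, does not separate the two compounds.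

Compound 3, `O=C(/C=C/c1cc2ccccc2[nH]c1=O)c1ccc(Cl)cc1`, is not yet measured. It differs from compound 2 by chloro in place of hydroxy on an aromatic carbon, that is, on an aromatic carbon of a six-membered aromatic ring of carbon only, para to a large group. For the measured compounds named here, no measured step swaps a hydroxy for a chloro; the one step in hand, from compound 1 to compound 2, changed the same ring at the same kind of position and moved the number by an amount within the scatter. On that basis the step of a 1.1-fold lower number from compound 2 to compound 3 (0.04 log units; within the scatter) is expected to stay within the scatter. The estimate for compound 3 in this assay is therefore 3500 nM, with a range from 1400 nM to 9000 nM.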

Compound 3, concentration for 50% growth inhibition: 5050 nM
For compound 3 the middle estimate is 1.4-fold (0.16 log units) below the measured one, within the range that was stated.
By their numbers in this assay, from the lowest: compounds 1, 2 and 3 (each within the scatter of the next).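

In this assay, the earlier step kept an oxygen on the ring, whereas compound 3 carries chloro at the same place, so the attached atom itself now differs. Even so, the step of a 1.3-fold higher number from compound 2 to compound 3 (0.12 log units; within the scatter) does not separate the two compounds, and neither does the step of a 1.4-fold higher number from compound 1 to compound 3 (0.15 log units; within the scatter), so in this one cell assay the oxygen is not required for a number in this range, and losing the hydrogen-bond donor and acceptor counted for hydroxy brings no change beyond the scatter. Nothing measured here says why the three compounds stand so close together.

The compounds shown leave open whether this position responds at all: an amine, a carboxylic acid or a longer chain such as butoxy could show whether a group very different from hydroxy, methoxy and chloro moves the number beyond the scatter, and plain hydrogen at this place would show whether any group is needed there. They also leave open how much of the growth inhibition depends on the shared core, which is the same in all three compounds.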